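From a Urea to an Amide: Estimating Compound 3

The compounds below may be only part of what the source reports. "The series", "measured", "known", "first", "only" and "open" are said of these compounds alone.

Compound 1 `O=C(Nc1cccc(-n2cc(-c3ccncc3)c(-c3cc(O)cc(Cl)c3)n2)c1)Nc1ccc(Cl)c(C(F)(F)F)c1` and compound 2 `COc1cc(Cl)cc(-c2nn(-c3cccc(NC(=O)Nc4ccc(Cl)c(C(F)(F)F)c4)c3)cc2-c2ccncc2)c1` share one core. In a functional assay on CAKI-1 cells (Homo sapiens) for inhibition, read by sulforhodamine B assay, with a stated time of 48 h, tested at 10 uM (on this read-out higher numbers stand for a weaker effect at the one concentration tested and lower numbers for a stronger effect), compound 1 gives 29.1%, and compound 2 gives 9.38%, the lowest of the two numbers; the step of a number 19.7 percentage points lower from compound 1 to compound 2 (beyond the scatter) is the only one measured. Compound 3 `COc1cc(Cl)cc(-c2nn(-c3cccc(NC(=O)c4cccc(C(F)(F)F)c4)c3)cc2-c2ccncc2)c1` differs from compound 2 by 3-(trifluoromethyl)phenyl in place of (4-chloro-3-(trifluoromethyl)phenyl)amino on a carbonyl carbon. Going by the values given here, no measured step touches this part of the molecule, so the measured step offers no guide to the size or direction of this change. Compound 3 is therefore expected, with wide uncertainty, to come in at 30% (from 8% to 65%), an estimated step of a number 20.6 percentage points higher from compound 2 to compound 3 (beyond the scatter).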

Compound 3, a percentage reported as activity, at one concentration (the size of the read-out at that concentration, not a potency): 54%
Estimate against measurement, compound 3: 24 percentage points below; low and high end bracket the measured number.
By their numbers in this assay, from the lowest: compound 2; then compound 1; then compound 3.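

In this assay the change on the carbonyl carbon gives a number 44.6 percentage points higher from compound 2 to compound 3 (beyond the scatter) and so weakens the effect, showing that this end of the molecule strongly affects the read-out. The change removes the amino nitrogen, with its hydrogen-bond donor, and the chlorine together, so the compounds cannot separate their contributions. No measurement here explains the step.

Going by these compounds, it remains open which loss matters more. A urea carrying 3-(trifluoromethyl)phenylamino, or an amide carrying 4-chloro-3-(trifluoromethyl)phenyl, would change only one of the two.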